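This account rests on a few compounds, and the source may have more. Where it says the series, first, only, none or still open, it means among the compounds named here.

Compound 1 `COCc1cccc2c1CC[C@H]2c1ncc[nH]1`: 69%
Compound 2 `COCc1c(F)ccc2c1CC[C@H]2c1ncc[nH]1`: 59%
Compound 3 `COCc1ccc(F)c2c1CCC2c1ncc[nH]1`: 49%

In a functional assay on CHO cells for agonist activity at Alpha-1A adrenergic receptor (Homo sapiens), read by fluorescence and calcium flux (on this read-out higher numbers stand for larger maximal responses and lower numbers for smaller maximal responses), compound 1 gives the highest of the three numbers shown. The nearest is compound 2, and the step of a number 10 percentage points lower from compound 1 to compound 2 (within the scatter) is within the scatter, so the two cannot be ordered. Compound 3 stands further off at 49%, a gap that does lie beyond the scatter.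

Compound 4 `c1cc(Cn2cccn2)c2c(c1)[C@H](c1ncc[nH]1)CC2` has not been measured in this assay. It differs from compound 1 as follows: 1H-pyrazol-1-yl in place of methoxy on a saturated chain carbon bound to an aromatic carbon. Within the data shown here, none of the measured steps bears on this change: the only measured step, a number 10 percentage points lower from compound 1 to compound 2 (within the scatter), concerns a fluoro in place of hydrogen on an aromatic carbon, not the saturated chain carbon where the new group enters. The data therefore give no direction, and the step of a number 9 percentage points lower from compound 1 to compound 4 (within the scatter) is expected to stay within the scatter, with a wide range. Compound 4 is estimated at 60%, between 40% and 80%.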

Compound 4, largest response reached (Emax), in percent of the reference or control that the assay uses: 69%
Beside the measured number, compound 4's estimate is 9 percentage points below it; measured number inside the range.
By their numbers in this assay, from the lowest: compounds 3, 2, 1 and 4 (each within the scatter of the next, the first and the last beyond it).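

In this assay, putting 1H-pyrazol-1-yl in place of methoxy on a saturated chain carbon bound to an aromatic carbon gives no change at the digits printed from compound 1 to compound 4 (within the scatter) in the maximal response. Among these compounds, the earlier compounds differed only by fluoro on the aromatic ring, so this is the first reading at the saturated chain carbon: a group of 5 heavy atoms with a five-membered aromatic ring can stand where a ringless group of 2 heavy atoms stood, with no step beyond the scatter. No available evidence accounts for this result.

On these data alone, what an amine, a carboxylic acid or a longer chain would do at this place stays open. As far as these compounds go, it also stays open whether fluoro on an aromatic carbon would give a similar step alongside (1H-pyrazol-1-yl)methyl.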